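The source may hold more compounds than are shown below. What is called first, only, known or untested is meant among the compounds shown, and "the series" means these compounds.

Working notes on the thiophene series, read-out a functional assay, with a stated time of 150 min, tested at 5 ug/mL; on this read-out higher numbers stand for a stronger effect at the one concentration tested and lower numbers for a weaker effect.

The common core carries an arylamino group, a methyl, an acid or ester, and an aroyl group. Compound 1, `COC(=O)c1c(Nc2ccc(OC)cc2)sc(C(=O)c2ccc(OC)cc2)c1C`, the methyl ester with a methoxyphenylamino group, gives 4.29% in this assay. Compound 2, `COc1ccc(C(=O)c2sc(Nc3ccccc3)c(C(=O)O)c2C)cc1`, the free acid with an unsubstituted phenylamino group, gives 19.6% in this assay. Compound 3, `COc1ccc(C(=O)c2sc(Nc3ccc(C)cc3)c(C(=O)O)c2C)cc1`, the free acid with a 4-methylphenylamino group, is reported in this assay as "not active" (no number reported); no number stands for it, so its place on the scale is not fixed.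

Compound 4, `COc1ccc(Nc2sc(C(=O)c3ccc(OC)cc3)c(C)c2C(=O)O)cc1`, has not been measured in this assay. Its difference from compound 3 is methoxy in place of methyl on an aromatic carbon. Going by the values given here, no step between measured compounds describes this change, so the size of the step cannot be read from the data. Given that compound 3 was reported without activity and that compound 1, which shares the methoxyphenylamino group, gives 4.29%, compound 4 is expected to sit low, with only a small step upward from compound 3 at most, within the usual scatter. For compound 4 the expected value in this assay is 8%, with a range from 0% to 22%.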

Compound 4, a percentage reported as activity, at one concentration (the size of the read-out at that concentration, not a potency): 20.2%
Compound 4: middle estimate off by 12.2 percentage points, on the low side, and the stated range covers the measured number.
By their numbers in this assay, from the lowest: compound 1; then compounds 2 and 4 (each within the scatter of the next).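

In this assay, methoxy in place of hydrogen on the aromatic carbon para to a large group gives a number 0.6 percentage points higher from compound 2 to compound 4 (within the scatter), so with the free acid in place this change leaves the read-out within the scatter. Going by these compounds alone, with the (4-methoxyphenyl)amino group held constant, hydrogen in place of methyl on the oxygen next to a carbonyl group gives a number 15.9 percentage points higher from compound 1 to compound 4 (beyond the scatter), the first one-place comparison of the methyl ester with the free acid, and a modest one. The methyl-to-methoxy step from compound 3 cannot be read, as compound 3 has no number on this scale.

Nothing at hand gives a reason for either step. Open, from the compounds shown here alone, is how a chloro or dimethylamino group at this place, or a primary amide in place of the acid, would read out.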